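The source may hold more compounds than are shown below. What is called first, only, known or untested is meant among the compounds shown, and "the series" means these compounds.

Three compounds share one core and are compared in an assay on Huh-7 cells for agonist activity at Bile acid receptor (Homo sapiens), read by a luciferase reporter; on this read-out lower numbers stand for an effect already at smaller amounts and higher numbers for an effect only at larger amounts of compound. Compound 1 `CC(C)c1onc(-c2c(Cl)cccc2Cl)c1COc1ccc(-c2nc3cc(C(=O)O)ccc3n2C)cc1` gives 25.8 nM. Compound 2 `CCC(CC)n1c(-c2ccc(OCc3c(-c4c(Cl)cccc4Cl)noc3C(C)C)cc2)nc2ccc(C(=O)O)cc21` gives 0.8 nM. Compound 3 `CCn1c(-c2ccc(OCc3c(-c4c(Cl)cccc4Cl)noc3C(C)C)cc2)nc2ccc(C(=O)O)cc21` gives 2.31 nM, the second highest of the three numbers. Among the measured compounds shown here, the only single-point change measured here is a 2.9-fold higher number from compound 2 to compound 3 (0.46 log units; beyond the scatter), a modest rise on shortening the branched chain on the aromatic nitrogen to ethyl. For the measured compounds named here, compound 1 and compound 3 differ in more than one place, so their values show only that compound 1 sits far higher.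

Compound 4 `CC(C)c1onc(-c2c(Cl)cccc2Cl)c1COc1ccc(-c2nc3ccc(C(=O)O)cc3n2C(C)C)cc1` is the next step from compound 3. The change is methyl in place of hydrogen on a saturated chain carbon bound to an aromatic nitrogen and a saturated chain carbon. Read one bond further out, the ethyl chain on the aromatic nitrogen becomes isopropyl, a move back toward the longer branched chain of compound 2. The step from compound 2 to compound 3 bears directly on it: a larger branched chain at that nitrogen went with a lower number, and the reverse move is now taken part of the way. A lowering somewhat smaller than that step is therefore expected, landing between compound 2 and compound 3.

Compound 4 is expected to give about 1.3 nM, within roughly 0.5 nM to 3.5 nM. That estimate corresponds to an expected step of a 1.8-fold lower number from compound 3 to compound 4 (0.25 log units; within the scatter).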

Compound 4, half-maximal effective concentration: 3.39 nM
Beside the measured number, compound 4's estimate is 2.6-fold (0.42 log units) below it, within the range that was stated.
By their numbers in this assay, from the lowest: compound 2; then compounds 3 and 4 (each within the scatter of the next); then compound 1.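

Going from ethyl to isopropyl on the aromatic nitrogen gives, in this assay, a 1.5-fold higher number from compound 3 to compound 4 (0.17 log units; within the scatter), so adding this one methyl to the chain has no effect that can be told apart from ordinary measurement scatter. The comparison with the larger group does stand out: isopropyl in place of pentan-3-yl gives a 4.2-fold higher number from compound 2 to compound 4 (0.63 log units; beyond the scatter), which places compound 2 apart from compound 4 and shows that, among these three groups, only pentan-3-yl goes with a clearly lower number, so the number does not fall evenly as the chain on this nitrogen grows. No independent evidence is available to explain why these groups compare this way.

On these data alone, it remains open whether the low number of compound 2 depends on branching or simply on the size of the group, which a straight butyl chain or a pentyl chain on the same nitrogen could help separate. A cyclopentyl ring there, which ties the two arms of the branch together, or a chain ending in a hydroxyl group, would test further how much this position tolerates.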